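A few compounds are considered here, and "the series" means these few. Any claim that something is new, unique, unknown or untested is made for them only; others in the source may bear on it.

In an ADME assay on HEK293 cells (Homo sapiens) for cytotoxicity, with a stated time of 6 h (on this read-out lower numbers stand for higher toxicity in this test and higher numbers for lower toxicity in this test), compound 1 (`CCNc1nc(N)nc2ccccc12`) gives > 25000 nM, which is a limit of the assay and not a number. Compound 2 (`CCCNc1nc(N)nc2ccccc12`) gives > 25000 nM, again a limit. Compound 3 (`CCCCNc1nc(N)nc2cccc(OC)c12`) gives > 25000 nM, also a limit, so its place on the scale is known only from that bound. Compound 1, compound 2 and compound 3 all stand at the limit of > 25000 nM in this assay, at which 3 of the 3 values shown sit.

Compound 4 (`CCCCNc1nc(N)nc2cccc(OCCOC)c12`) turns the methoxy of compound 3 into 2-methoxyethoxy: methoxymethyl in place of hydrogen on a saturated chain carbon bound to an oxygen on an aromatic ring. Within the data shown here, the only measured step of a similar kind, a methyl in place of hydrogen on a saturated chain carbon, is a step that the two limits leave unreadable from compound 1 to compound 2, so it offers no size to carry over. Nothing measured therefore points to a shift in either direction in this assay. The estimated outcome is expected to be a step that the limit leaves unreadable from compound 3 to compound 4. No change beyond the scatter is expected, and a report of only a limit is likely. For compound 4, the estimated half-maximal cytotoxic concentration is 30000 nM, with an expected range of 12000 nM to 60000 nM.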

Compound 4, half-maximal cytotoxic concentration: 10000 nM
Beside the measured number, compound 4's estimate is 3.0-fold (0.48 log units) above it, outside the stated range (below it).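

In this assay, the change from methoxy to 2-methoxyethoxy gives an at least 2.5-fold lower number from compound 3 to compound 4 (0.39 log units; beyond the scatter), so a methoxymethyl on a saturated chain carbon bound to an oxygen on an aromatic ring can lower the number beyond the scatter. Among these compounds, the one earlier step between compounds that differ in one place cannot be read, so the earlier compounds gave no sign that any change could register in this test. Compound 4 is the only compound shown with a number rather than a limit: the limit of > 25000 nM in this assay, at which 3 of the 4 values shown sit.

The compounds shown leave open whether the oxygen in the new chain matters or whether a plain propyl or butyl chain in place of the methoxymethyl would give the same result. They also leave open how an amine or a carboxylic acid in that place would read.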